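A few compounds are considered here, and "the series" means these few. Any claim that something is new, unique, unknown or untested is made for them only; others in the source may bear on it.

Compound 2 `COc1cc2c(Oc3c(F)cc(NC(=O)NN4C(=O)CSC4c4c(F)cccc4F)cc3F)ccnc2cc1OCCCN1C[C@H]2CCCC[C@H]2C1` carries, on a saturated chain carbon three bonds along the chain from an oxygen on an aromatic ring, an amine built into a five-membered ring fused to a six-membered carbon ring. Among the compounds with values here, in a functional assay on A549 cells (Homo sapiens) for antiproliferative activity, read by MTT assay, with a stated time of 72 h (on this read-out higher numbers stand for weaker inhibition and lower numbers for stronger inhibition), compound 2 gives 1930 nM, one of only two numbers measured so far; the other comes from compound 1 `COc1cc2c(Oc3c(F)cc(NC(=O)NN4C(=O)CSC4c4c(F)cccc4F)cc3F)ccnc2cc1OCCCN1CCC(C)CC1`, which in this assay gives 970 nM, and the step of a 2.0-fold higher number from compound 1 to compound 2 (0.30 log units; within the scatter) lies within the scatter, so neither compound can be called the stronger. Compound 3 `CCN(CC)CCCOc1cc2nccc(Oc3c(F)cc(NC(=O)NN4C(=O)CSC4c4c(F)cccc4F)cc3F)c2cc1OC` alters the same place once more: a group of 5 heavy atoms (4 carbon, 1 nitrogen; no ring) in place of a group of 9 heavy atoms (8 carbon, 1 nitrogen; one five-membered non-aromatic ring with 1 hetero atom, one six-membered non-aromatic ring of carbon only), on a saturated chain carbon, three bonds along the chain from an oxygen on an aromatic ring. Within the data shown here, the one measured step at this position is the only guide, and because a 2.0-fold higher number from compound 1 to compound 2 (0.30 log units; within the scatter) changed the number only within the scatter, no shift beyond the scatter is expected here either. Compound 3 is therefore expected to give about 1300 nM in this assay, within a range from 500 nM to 3500 nM, an expected step of a 1.5-fold lower number from compound 2 to compound 3 (0.17 log units; within the scatter).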

Compound 3, half-maximal inhibitory concentration: 450 nM
For compound 3 the middle estimate is 2.9-fold (0.46 log units) above the measured one, and the stated range ends above it.
By their numbers in this assay, from the lowest: compound 3; then compounds 1 and 2 (each within the scatter of the next).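

In this assay, this position now shows changes beyond the scatter: diethylamino in place of the fused-ring amine gives a 4.3-fold lower number from compound 2 to compound 3 (0.63 log units; beyond the scatter), and diethylamino in place of 4-methylpiperidin-1-yl gives a 2.2-fold lower number from compound 1 to compound 3 (0.33 log units; beyond the scatter). Both steps are modest, but they show that the amine at the end of this chain can move the number, with open-chain diethylamino giving stronger inhibition than either ring-bearing amine, while those two remain within the scatter of each other. Nothing available here accounts for this difference.

Still open, as far as these compounds go, is whether a smaller open-chain amine such as dimethylamino would follow diethylamino, or whether a ring amine such as morpholine would fall with the other ring amines. A longer chain carrying diethylamino also remains an open case.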